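This account rests on a few compounds, and the source may have more. Where it says the series, first, only, none or still open, it means among the compounds named here.

Series notes. In a functional assay on RAW264.7 cells (Mus musculus) for inhibition, read by Griess assay, with a stated time of 24 h (on this read-out higher numbers stand for weaker inhibition and lower numbers for stronger inhibition), compound 1 `COc1cc(-c2c(C=O)c(O)cc3cc(OC)c(O)cc23)ccc1O` gives 130 nM, the lowest of the two numbers in hand. Compound 2 `COc1cc([C@H]2c3cc(O)c(O)cc3C=C(C=O)[C@@H]2CO)ccc1O` gives 380 nM, a gap from compound 1 that lies beyond the scatter. Compound 3 `COc1cc(-c2c(C=O)ccc3cc(OC)c(O)cc23)ccc1O` is not yet measured in this assay; it differs from compound 1 by hydrogen in place of hydroxy on an aromatic carbon. For the measured compounds named here, no pair of measured compounds shows a step of this kind, so the direction rests on expectation alone. For compound 3 a modest weakening is expected, a 1.9-fold higher number from compound 1 to compound 3 (0.28 log units; within the scatter). Compound 3 is accordingly estimated at 250 nM, with a range from 100 nM to 700 nM.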

Compound 3, half-maximal inhibitory concentration: 570 nM
For compound 3 the middle estimate is 2.3-fold (0.36 log units) below the measured one; low and high end bracket the measured number.
By their numbers in this assay, from the lowest: compound 1; then compounds 2 and 3 (each within the scatter of the next).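

In this assay, for the compounds shown here, hydrogen in place of the hydroxy ortho to the formyl group gives a 4.4-fold higher number from compound 1 to compound 3 (0.64 log units; beyond the scatter) and so provides the first single-place step. This aromatic carbon is therefore sensitive to substitution, and hydrogen does not match hydroxy there. Nothing in hand accounts for the size of this step. On these data alone, whether an amine or a methoxy group on this carbon would hold the number of compound 1 stays open. So does whether the same step would appear on the core of compound 2.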